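A few compounds are considered here, and "the series" means these few. Any claim that something is new, unique, unknown or untested is made for them only; others in the source may bear on it.

Among the measured compounds shown here, in a functional assay on Caco-2 cells (Homo sapiens) for cytotoxicity, read by MTT assay, with a stated time of 4 h (on this read-out lower numbers stand for stronger inhibition and higher numbers for weaker inhibition), compound 1 `CCCCCCCCCCCC(=O)OC[C@H]1O[C@@H](O[C@@H]2OC=C(C(=O)OC)[C@H]3C[C@H](OC(C)=O)[C@H](C)[C@@H]23)[C@H](OC(C)=O)[C@@H](OC(C)=O)[C@@H]1OC(C)=O` gives 0.42 ug/mL and compound 2 `COC(=O)C1=CO[C@@H](O[C@@H]2O[C@H](COC(=O)C=C(C)C)[C@@H](OC(C)=O)[C@H](OC(C)=O)[C@H]2OC(C)=O)[C@@H]2[C@@H](C)[C@@H](OC(C)=O)C[C@H]12` gives 0.8 ug/mL, so compound 2 stands within the scatter of the only other measured number. Compound 3 `COC(=O)C1=CO[C@@H](O[C@@H]2O[C@H](COC(=O)c3cccc([N+](=O)[O-])c3)[C@@H](OC(C)=O)[C@H](OC(C)=O)[C@H]2OC(C)=O)[C@@H]2[C@@H](C)[C@@H](OC(C)=O)C[C@H]12` differs from compound 2 at the ester on the shared core: 3-nitrophenyl in place of 2-methylprop-1-en-1-yl on a carbonyl carbon. For the measured compounds named here, the one measured step bearing on this, a 1.9-fold higher number from compound 1 to compound 2 (0.28 log units; within the scatter), is an exchange on the same carbonyl carbon and stays within the scatter. Going by the values given here, no measured compound carries an aromatic ring there, so this is a weak guide, and no shift beyond the scatter is expected in this assay. The expected step is a 1.1-fold lower number from compound 2 to compound 3 (0.06 log units; within the scatter). For compound 3 the estimated value is 0.7 ug/mL, with an expected range of 0.25 ug/mL to 2 ug/mL.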

Compound 3, half-maximal inhibitory concentration: 1 ug/mL
For compound 3 the middle estimate is 1.4-fold (0.15 log units) below the measured one; measured number inside the range.
By their numbers in this assay, from the lowest: compounds 1, 2 and 3 (each within the scatter of the next, the first and the last beyond it).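

In this assay, among the compounds shown here, 3-nitrophenyl on this carbonyl carbon puts an aromatic ring at the ester for the first time, and the exchange for 2-methylprop-1-en-1-yl gives a 1.3-fold higher number from compound 2 to compound 3 (0.10 log units; within the scatter). For the compounds shown here, exchanging undecyl for 3-nitrophenyl gives a 2.4-fold higher number from compound 1 to compound 3 (0.38 log units; beyond the scatter), the first step at this position to pass the scatter. No measurement at hand accounts for either step.

As far as these compounds go, it remains open whether the aromatic ring or the nitro group matters to these numbers. A plain phenyl, an aminophenyl or a chain of intermediate length on this carbonyl carbon would separate those readings.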